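The source may report more compounds than this note shows. Statements on the series, on what has been measured and on what is new or still open speak of the compounds shown alone.

In a toxicity assay (RAW264.7 cells) for cytotoxicity, with Mus musculus as the target, read by MTT assay, with a stated time of 4 h (on this read-out lower numbers stand for stronger inhibition and higher numbers for weaker inhibition), compound 1 `O=c1oc2c(O)cccc2cc1-c1cccc(O)c1` gives > 100000 nM, which is a limit and not a number. Compound 3 `O=c1oc2cc(O)cc(O)c2cc1-c1ccccc1` gives > 100000 nM, which is also a limit. Both therefore stand at the limit of > 100000 nM in this assay, at which 2 of the 3 values shown sit. Compound 2 `O=c1oc2c(O)cccc2cc1-c1ccc(O)c(O)c1` gives a true number, 115000 nM. Compound 4 `O=c1oc2c(O)c(O)ccc2cc1-c1cccc(O)c1` differs from compound 1 by one change: hydroxy in place of hydrogen on an aromatic carbon. For the measured compounds named here, the only measured step of this kind is a step that the limit leaves unreadable from compound 1 to compound 2, so its size offers no direct guide. Still, compound 2 at 115000 nM shows no marked gain in this assay from an added hydroxy, so no step beyond the scatter is expected. The estimated step is a number no higher from compound 1 to compound 4 (the limit leaves the size open). For compound 4 the expected value is 100000 nM, with an estimated range of 40000 nM to 200000 nM.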

Compound 4, half-maximal inhibitory concentration: 398000 nM
The estimate for compound 4 lay 4.0-fold (0.60 log units) below the measured number, outside the stated range (above it).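

The step from compound 1 to compound 4 cannot be read, because compound 1 stands only at a limit: the limit of > 100000 nM in this assay, at which 2 of the 4 values shown sit. The compounds shown leave open how large a step hydroxy in place of hydrogen on an aromatic carbon brings.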